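The compounds below may be only part of what the source reports. "The series", "measured", "known", "first", "only" and "open" are said of these compounds alone.

Compound 1 `COc1ccc(C(N)=O)cc1/C=C/c1ccc(Cl)cc1`: 87 nM
Compound 2 `COc1ccc(C(N)=O)cc1/C=C/c1ccc(C(C)(C)C)cc1`: 370 nM
Compound 3 `COc1ccc(C(N)=O)cc1/C=C/c1ccc(Cl)cc1Cl`: 2600 nM

In a functional assay on HUVEC cells (Homo sapiens) for inhibition, with a stated time of 4 days (on this read-out lower numbers stand for stronger inhibition and higher numbers for weaker inhibition), compound 1 gives the lowest of the three numbers, 87 nM. Compound 4 `CCCOc1ccc(C(N)=O)cc1/C=C/c1ccc(Cl)cc1` differs from it at one place, where methoxy becomes propoxy: ethyl in place of hydrogen on a saturated chain carbon bound to an oxygen on an aromatic ring. The ethyl sits on a saturated chain carbon bound to an oxygen on an aromatic ring. Going by the values given here, no measured step changes that place, so the evidence is indirect. Elsewhere on the molecule, the data show a 4.3-fold higher number from compound 1 to compound 2 (0.63 log units; beyond the scatter), a modest step, and a 30-fold higher number from compound 1 to compound 3 (1.48 log units; beyond the scatter), a large one. Both moved away from the low number, so a modest rise seems the likeliest outcome, though with wide uncertainty. The expected change is a 4.0-fold higher number from compound 1 to compound 4 (0.60 log units; beyond the scatter). For compound 4, the estimated value is 350 nM, with an expected range of 100 nM to 1500 nM.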

Compound 4, half-maximal inhibitory concentration: 1300 nM
Beside the measured number, compound 4's estimate is 3.7-fold (0.57 log units) below it; the range from low to high includes it.
By their numbers in this assay, from the lowest: compound 1; then compound 2; then compounds 4 and 3 (each within the scatter of the next).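

This is the only step shown at this place: in this assay, changing methoxy to propoxy gives a 15-fold higher number from compound 1 to compound 4 (1.17 log units; beyond the scatter). Inhibition here is therefore sensitive to the length of this chain, since adding an ethyl of just 2 heavy atoms produces a large step. Nothing shown explains why the number rises.

Still open, as far as these compounds go, is how ethoxy, one carbon shorter than propoxy, would read out. From the compounds shown here alone, a free hydroxyl at this place, or a propoxy chain ending in an amine, also remains untested here.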